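Tert-butyl on the core of compound 1

This account rests on a few compounds, and the source may have more. Where it says the series, first, only, none or still open, it means among the compounds named here.

Measured so far in a functional assay on MDA-MB-231 cells (Homo sapiens) for antiproliferative activity, read by MTT assay, with a stated time of 24 h; on this read-out higher numbers stand for weaker inhibition and lower numbers for stronger inhibition:
- compound 1 `O=C(O)CC(NS(=O)(=O)c1ccccc1)c1ccccc1`: > 100000 nM (a limit)
- compound 2 `O=C(O)CC(NS(=O)(=O)c1ccc(F)cc1)c1ccccc1`: 88400 nM
- compound 3 `O=C(O)CC(NS(=O)(=O)c1cccc([N+](=O)[O-])c1)c1ccccc1`: > 100000 nM (a limit)

Not yet measured: compound 4 `CC(C)(C)c1ccc(C(CC(=O)O)NS(=O)(=O)c2ccccc2)cc1`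

Compound 1 stands at the limit of > 100000 nM in this assay, at which 2 of the 3 values shown sit, so it gives a limit and not a number. Compound 4 differs from it by tert-butyl in place of hydrogen on an aromatic carbon. Going by the values given here, two measured steps bear on this, both on the other aromatic ring, so only loosely. The fluoro step is an at least 1.1-fold lower number from compound 1 to compound 2 (0.05 log units; that floor lies within the scatter). The nitro step is a step that the two limits leave unreadable from compound 1 to compound 3. Neither supports a large move, so only a small shift to lower numbers is expected in this assay. The estimated step is an at least 1.4-fold lower number from compound 1 to compound 4 (0.15 log units; that floor lies within the scatter). For compound 4 the expected value is 70000 nM, with an estimated range from 25000 nM to 140000 nM.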

Compound 4, half-maximal inhibitory concentration: > 100000 nM
Compound 4: no number, only a limit; the forecaster's own chance of this, stated with the estimate: 50%; at least 1.4-fold (0.15 log units) between middle value and limit.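

Compound 1 and compound 4 both give only a limit in this assay, and the step between them cannot be read. The compounds shown leave open how far tert-butyl in place of hydrogen on an aromatic carbon moves the value.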